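The compounds below may be only part of what the source reports. "The series", "measured", "known", "first", "only" and "open" are said of these compounds alone.

Measured in an ADME assay on microsomes from liver (Mus musculus) for metabolic stability, read by LC-MS, with NADPH named in the record, with a stated time of 60 min, tested at 1 uM, in the absence of a further agent (on this read-out lower numbers stand for a less stable compound and higher numbers for a more stable compound), so far:
compound 1 `CC(=O)N[C@@H]1CCN(c2cc(C)nn3c(-c4ccc(C(F)(F)F)cc4)c(C)nc23)C1` | > 95%
compound 2 `CSc1ccc(-c2c(C)nc3c(N4CC[C@@H](NC(C)=O)C4)cc(C)nn23)cc1` | > 95%

Compound 1 with > 95% is reported only as a limit. Compound 2 with > 95% is likewise only a limit. Compound 2 therefore stands at the limit of > 95% in this assay, at which 2 of the 2 values shown sit, and has no exact value of its own.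

Compound 3 `CC(=O)N[C@@H]1CCN(c2cc(C)nn3c(-c4cccs4)c(C)nc23)C1` takes thiophen-2-yl in place of 4-(methylsulfanyl)phenyl on an aromatic carbon. Among the compounds with values here, the one measured step that bears on this place is a step that the two limits leave unreadable from compound 1 to compound 2 with methylsulfanyl in place of trifluoromethyl on an aromatic carbon. Within the data shown here, that step has no readable size, and no measured step exchanges the whole aromatic group. Given a step that the two limits leave unreadable from compound 1 to compound 2 no size can be carried over, so only a modest fall is expected in this assay and compound 3 may well remain at the limit. The expected change is a number at least 5 percentage points lower from compound 2 to compound 3 (that floor lies within the scatter) as an estimate only. For compound 3 the estimated value is 90% with an expected range of 65% to 100% in this read-out.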

Compound 3, percent of the compound remaining: > 95%
Compound 3: only a limit was reported; the forecaster's own chance of this, stated with the estimate: 45%; middle value at least 5 percentage points away from the limit.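

No step can be read among compound 1, compound 2 and compound 3 in this assay, as each is reported only as a limit, and all three sit at the same one: the limit of > 95% in this assay, at which 3 of the 3 values shown sit. The compounds shown leave open whether 4-(trifluoromethyl)phenyl, 4-(methylsulfanyl)phenyl and thiophen-2-yl differ in the percent of compound remaining.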